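Shortening the ethoxy group of compound 2 to methoxy

The compounds below may be only part of what the source reports. "The series", "measured", "known", "first", "only" and "open" are said of these compounds alone.

compound 1 `COc1ccc(Br)cc1C(C)NC(=O)NS(=O)(=O)c1ccc(C)cc1` | > 300000 nM (a limit)
compound 2 `CCOc1ccc(Br)cc1C(C)NC(=O)N(C)S(=O)(=O)c1ccc(C)cc1` | 28600 nM

For the measured compounds named here, in a functional assay on thoracic aorta (Rattus norvegicus, strain Wistar), with a stated time of 15 min (a lower number here means that less compound is needed, a higher number that more compound is needed for the effect), compound 2 holds the only actual number (28600 nM). The entry for compound 1 (> 300000 nM) is a limit of the assay. Compound 3 `COc1ccc(Br)cc1C(C)NC(=O)N(C)S(=O)(=O)c1ccc(C)cc1` has not yet been measured. It departs from compound 2 by a single change (hydrogen in place of methyl on a saturated chain carbon bound to an oxygen on an aromatic ring), hydrogen in place of methyl on a saturated chain carbon bound to an oxygen on an aromatic ring, which turns ethoxy to methoxy. Going by the values given here, no measured pair isolates this change. A small move towards a higher number in this assay is expected, an estimated step of a 1.4-fold higher number from compound 2 to compound 3 (0.15 log units; within the scatter). The estimate for compound 3 is 40000 nM, with an expected range from 14000 nM to 120000 nM.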

Compound 3, half-maximal effective concentration: 19100 nM
Compound 3: middle estimate off by 2.1-fold (0.32 log units), on the high side, and the stated range covers the measured number.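

In this assay, shortening ethoxy to methoxy on a saturated chain carbon bound to an oxygen on an aromatic ring leaves the two compounds within the scatter, with a 1.5-fold lower number from compound 2 to compound 3 (0.18 log units; within the scatter). A second single change can now be read: methyl in place of hydrogen on an amide-type nitrogen gives an at least 15-fold lower number from compound 1 to compound 3 (1.19 log units; beyond the scatter). That larger step rests on a limit for compound 1, so its full size stays unknown: the limit of > 300000 nM in this assay, at which 1 of the 3 values shown sits.

As far as these compounds go, whether propoxy or a free hydroxy group at the ether position would shift the number remains open. So does the effect of ethyl on the amide-type nitrogen.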